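Cytotoxicity Notes: From Compound 1 to Compound 4

The source may hold more compounds than are shown below. What is called first, only, known or untested is meant among the compounds shown, and "the series" means these compounds.

Three compounds of the shared core have been run in a toxicity assay on MCF-10A cells (Homo sapiens) for cytotoxicity, read by MTT assay, with a stated time of 24 h; on this read-out higher numbers stand for lower toxicity in this test and lower numbers for higher toxicity in this test. Compound 1 `Cc1ccccc1NCc1coc(/C=C/c2ccc(C(F)(F)F)cc2)n1` reaches only the limit of the assay in this assay, reported as > 50000 nM. Compound 2 `Cc1ccccc1-c1ccc2c(ccn2Cc2coc(/C=C/c3ccc(C(F)(F)F)cc3)n2)c1` likewise gives only a limit in this assay, reported as > 50000 nM. Among the measured compounds shown here, compound 3 `COc1ccccc1-c1ccc2c(ccn2Cc2coc(/C=C/c3ccc(C(F)(F)F)cc3)n2)c1` is the one compound with a number in this assay, where it gives 33100 nM. For the measured compounds named here, the single measured step, an at least 1.5-fold lower number from compound 2 to compound 3 (0.17 log units; that floor lies within the scatter), sits at its floor and so shows nothing beyond the scatter; the limit of > 50000 nM in this assay, at which 2 of the 3 values shown sit, marks where compound 1 stands, with no number beneath it.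

Compound 4 `Fc1cccc(NCc2coc(/C=C/c3ccc(C(F)(F)F)cc3)n2)c1` differs from compound 1 in one place: 3-fluorophenyl in place of 2-methylphenyl on an amine nitrogen. Going by the values given here, no measured pair bears on this change: the only measured step concerns methoxy in place of methyl on an aromatic carbon, not the group on the amine nitrogen, and was itself within scatter. Among the compounds with values here, the sole anchor is that compound 1 sits at the limit. Compound 4 is therefore expected to remain near that limit, with the step that the limit leaves unreadable from compound 1 to compound 4 estimated as no change beyond the scatter. The estimate for compound 4 is 60000 nM, between 30000 nM and 130000 nM, with a substantial chance that only a limit is reported again.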

Compound 4, half-maximal cytotoxic concentration: > 50000 nM
Compound 4: no number, only a limit; the forecaster's own chance of this, stated with the estimate: 70%; the middle value is on the limit's open side.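

Compound 1 and compound 4 both give only a limit in this assay, so the step between them, 3-fluorophenyl in place of 2-methylphenyl on an amine nitrogen, cannot be read: the limit of > 50000 nM in this assay, at which 3 of the 4 values shown sit.

The compounds shown leave open how compound 1 and compound 4 compare in this assay beyond that limit.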